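Swapping the Aryl Ring on Compound 2: Expected Tolerance

The compounds below may be only part of what the source reports. "The series", "measured", "known", "first", "only" and "open" are said of these compounds alone.

Measured so far:
compound 1, `COc1ccccc1-c1cc(=O)c2cc(NC(C)=O)ccc2o1`: 226000 nM
compound 2, `COc1ccccc1-c1oc2ccc(NC(C)=O)cc2c(=O)c1OC`: 154000 nM

Of the compounds shown here, two have been measured in an ADME assay on MT4 cells (Homo sapiens) for cytotoxicity, read by MTT assay, with a stated time of 4 days; a lower number here means that less compound is tolerated, a higher number that more compound is tolerated. Compound 1 `COc1ccccc1-c1cc(=O)c2cc(NC(C)=O)ccc2o1` gives 226000 nM, and compound 2 `COc1ccccc1-c1oc2ccc(NC(C)=O)cc2c(=O)c1OC` gives 154000 nM. Going by the values given here, compound 2 stands nearest compound 1, and the only measured step, a 1.5-fold lower number from compound 1 to compound 2 (0.17 log units; within the scatter), lies within the scatter, so the two are not separated by this assay. That step is a methoxy in place of hydrogen on an aromatic carbon of the shared core.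

Compound 3 `COc1c(-c2cccc(F)c2)oc2ccc(NC(C)=O)cc2c1=O` has not been measured. It differs from compound 2 in one place: 3-fluorophenyl in place of 2-methoxyphenyl on an aromatic carbon. Among the compounds with values here, no measured step changes the aryl ring attached to the core; the single step available, a 1.5-fold lower number from compound 1 to compound 2 (0.17 log units; within the scatter), concerns a different place and was within the scatter. Nothing in the data therefore points to a step beyond the scatter in this assay, in either direction. Compound 3 is accordingly expected to give about 150000 nM, with a range from 60000 nM to 350000 nM. The estimated step is a 1.0-fold lower number from compound 2 to compound 3 (0.01 log units; within the scatter).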

Compound 3, half-maximal cytotoxic concentration: 210000 nM
The estimate for compound 3 lay 1.4-fold (0.15 log units) below the measured number; measured number inside the range.
By their numbers in this assay, from the lowest: compounds 2, 3 and 1 (each within the scatter of the next).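

In this assay the aryl ring on the aromatic carbon next to the ring oxygen has now been changed, and the exchange of 2-methoxyphenyl for 3-fluorophenyl gives a 1.4-fold higher number from compound 2 to compound 3 (0.13 log units; within the scatter). Going by these compounds alone, the earlier step concerned a different place, so this is the first reading at this position, and it does not separate the two compounds. The exchange replaces a group counted with one hydrogen-bond acceptor by one counted with none, and swaps a methoxy group for a fluorine on the phenyl ring, yet neither difference shows up as a step beyond the scatter, and no measurement on hand offers a reason for this result.

Because 2-methoxyphenyl and 3-fluorophenyl differ both in the group carried and in where it sits on the phenyl ring, this single pair cannot tell those two differences apart. As far as these compounds go, it also remains open whether an aryl ring carrying an amine or a carboxylic acid, or a longer chain in place of the aryl ring, would give a step beyond the scatter at this position.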